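Cyclohexyl for butylcarbonyl on the ring nitrogen of compound 3

The compounds below may be only part of what the source reports. "The series", "measured", "known", "first", "only" and "open" are said of these compounds alone.

Of the compounds shown here, three with a shared core have been tested in an assay on CHO cells for displacement of a labelled ligand from adenosine receptor A1 (Homo sapiens), read by scintillation counting, with a stated time of 1 h, tested at 1 uM; a higher number here means more inhibition at the concentration tested (going by the name of the read-out), a lower number less inhibition. Compound 1 `Cc1cccc(-c2cnc(N)nc2-c2ccccc2)c1` reaches > 80% in this assay, which is a limit of the assay and not a number (the limit of > 80% in this assay, at which 1 of the 3 values shown sits). Compound 2 `Cc1ccc(-c2cnc(N)nc2-c2ccccc2)cc1` gives 51% in this assay. Compound 3 `CCCCC(=O)Nc1ncc(-c2cccc(Cl)c2)c(-c2ccccc2)n1` gives 52% in this assay, the higher of the two plain numbers, though its gap to compound 2 lies within the scatter, so the two cannot be ranked against each other.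

Compound 4 `Clc1cccc(-c2cnc(NC3CCCCC3)nc2-c2ccccc2)c1` differs from compound 3 in one place: cyclohexyl in place of butylcarbonyl on a nitrogen on an aromatic ring. No pair of measured compounds shows a change of this kind, so the shown numbers set neither size nor direction for the step. The account treats the outcome as open and expects, at most, a small gain over compound 3 that may not exceed the scatter. Compound 4 is therefore expected at 60% in this assay, with a range from 30% to 85%. The expected step of a number 8 percentage points higher from compound 3 to compound 4 (within the scatter) is put forward only as an estimate.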

Compound 4, a percentage reported as inhibition, at one concentration (the size of the read-out at that concentration, not a potency): 58%
Compound 4: the middle estimate sits 2 percentage points above what was measured; the range from low to high includes it.
By their numbers in this assay, from the lowest: compounds 2, 3 and 4 (each within the scatter of the next). At a limit, above all of these: compound 1.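

In this assay, for the compounds shown here, cyclohexyl in place of butylcarbonyl on the nitrogen on an aromatic ring gives a number 6 percentage points higher from compound 3 to compound 4 (within the scatter), the first step that can be read at this place. The change removes the carbonyl, with its hydrogen-bond acceptor, and brings in a six-membered non-aromatic ring of carbon only, with the same count of heavy atoms, yet the two readings cannot be told apart. An amide and a cycloalkyl group on this nitrogen are therefore equally compatible with inhibition at this level, so this single exchange shows no preference between them.

From the compounds shown here alone, whether a cyclopentyl ring, a phenyl ring or a longer straight alkyl chain on this nitrogen would move the reading beyond the scatter remains open. Compound 1 stands at a limit of the assay and not at a number, and it differs from compound 4 in more than one place: the limit of > 80% in this assay, at which 1 of the 4 values shown sits.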